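The compounds below may be only part of what the source reports. "The series", "measured", "known", "first", "only" and "open" are said of these compounds alone.

Compound 1 `Nc1nc(-c2ccc(Cl)cc2)cn1/N=C/c1cc2ccccc2nc1Cl` carries an aminoimidazole bearing a chlorophenyl group, joined through an imine to a chlorinated bicyclic core. In a functional assay on DLD-1 cells (Homo sapiens) for cytotoxicity, read by MTT assay, with a stated time of 48 h (a lower number here means a stronger inhibitor, a higher number a weaker inhibitor), compound 1 gives only a limit, > 50000 nM, which is the limit of > 50000 nM in this assay, at which 1 of the 3 values shown sits, rather than a measured number. Compound 2 `Cc1ccc2nc(Cl)c(/C=N/n3cc(-c4ccc(Cl)cc4)nc3N)cc2c1` differs from compound 1 by a single change, (methyl in place of hydrogen on an aromatic carbon), and in this assay compound 2 gives 38900 nM. The step of an at least 1.2-fold lower number from compound 1 to compound 2 (0.10 log units; that floor lies within the scatter) is small and, since it starts from a limit, shows only that the methyl did not weaken the compound.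

Compound 3 `Nc1nc(-c2cccc3ccccc23)cn1/N=C/c1cc2ccccc2nc1Cl` replaces the chlorophenyl group with a naphthyl group on the same aminoimidazole; the difference between the core of compound 1 and the core of compound 3 is not broken down here. In this assay compound 3 gives 9480 nM, the lowest of the two numbers measured, with a gap to compound 2 that lies beyond the usual scatter.

Compound 4 `Cc1ccc2nc(Cl)c(/C=N/n3cc(-c4cccc5ccccc45)nc3N)cc2c1` has not yet been measured. It differs from compound 3 by methyl in place of hydrogen on an aromatic carbon, the same change as from compound 1 to compound 2. Within the data shown here, because the only measured instance of this change, an at least 1.2-fold lower number from compound 1 to compound 2 (0.10 log units; that floor lies within the scatter), stayed within the scatter, the step of a 1.3-fold lower number from compound 3 to compound 4 (0.10 log units; within the scatter) is expected to be small as well. The value expected for compound 4 in this assay is 7500 nM, with a likely range from 3000 nM to 20000 nM.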

Compound 4, half-maximal inhibitory concentration: 8300 nM
Beside the measured number, compound 4's estimate is 1.1-fold (0.04 log units) below it; low and high end bracket the measured number.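

In this assay, placing the methyl on the core of compound 3 leaves the number within the usual scatter (a 1.1-fold lower number from compound 3 to compound 4 (0.06 log units; within the scatter)), and the two cases carrying this change compare as follows: the same change on two cores in this assay, an at least 1.2-fold lower number (0.10 log units; that floor lies within the scatter) from compound 1 to compound 2 and a 1.1-fold lower number (0.06 log units; within the scatter) from compound 3 to compound 4; the limit leaves it open whether they differ.

On these data alone, compound 1 gives only a limit, so the size of the change on its core stays unknown, and the first case can say no more than that the methyl did not weaken the compound: the limit of > 50000 nM in this assay, at which 1 of the 4 values shown sits.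

Among these compounds, the result therefore shows that the methyl brought no change beyond the scatter on the one core where it can be fully read, but two cores are too few to show that it would behave the same way across the series, and the one step here beyond the scatter belongs to a different change, naphthalen-1-yl in place of 4-chlorophenyl (a 4.7-fold lower number from compound 2 to compound 4 (0.67 log units; beyond the scatter)).

The compounds shown leave open what other groups on this same aromatic carbon would do, such as an ethyl group, a methoxy group, a fluorine atom or an amine. They also leave open whether a larger step would appear with a carboxylic acid or a longer chain on the naphthalen-1-yl group.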